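The compounds below may be only part of what the source reports. "The series", "measured", "known", "first", "only" and "open" are said of these compounds alone.

Measured compounds:

compound 1, `COc1cc(OC)cc(N2CCN(C(=O)c3onc(C)c3-c3ccccc3)CC2)c1`, in a functional assay on HL-60 cells (Homo sapiens) for inhibition, read by MTT assay, with a stated time of 72 h (a lower number here means a stronger inhibitor, a higher number a weaker inhibitor), compound 1 gives 152 nM.
compound 2, `COc1ccc(-c2nc(C)oc2C(=O)N2CCN(c3cccc(Cl)c3)CC2)cc1O`, in this assay compound 2 gives "not active" (no number reported).
compound 3, `COc1ccc(Cl)cc1N1CCN(C(=O)c2oc(C)nc2-c2ccccc2F)CC1`, in this assay compound 3 gives 153 nM.

Compound 2 stands apart from the other two: for compound 1 and compound 3 a number was obtained in this assay, whereas for compound 2 the result is reported only as not active, so no single number places it on the same scale. Compound 1 and compound 3 sit within the usual scatter of each other, so nothing can be said about an order between them.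

The next compound, compound 4, `Cc1nc(-c2cccc(F)c2)c(C(=O)N2CCN(c3cccc(Cl)c3)CC2)o1`, has not yet been measured. It differs from compound 2 in one place: 3-fluorophenyl in place of 3-hydroxy-4-methoxyphenyl on an aromatic carbon. The rest of the molecule, including the core and the piperazine with its chlorophenyl, is kept.

Compound 2 has no number. For the measured compounds named here, no step can be computed from it to compound 4. The expectation rests on compound 1 and compound 3, both of which carry a plain or fluorinated phenyl at the corresponding site of their cores and both of which give numbers in this assay well within the measurable range. A move from an inactive result toward a measurable value is therefore the direction expected, though a value weaker than compound 1 and compound 3 would not surprise. Compound 4 is estimated at 400 nM, with a likely range from 90 nM to 3000 nM.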

Compound 4, half-maximal inhibitory concentration: 33.7 nM
For compound 4 the middle estimate is 12-fold (1.07 log units) above the measured one, outside the stated range (below it).
By their numbers in this assay, from the lowest: compound 4; then compounds 1 and 3 (each within the scatter of the next).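

Compound 2 has no number in this assay, only the result "not active", so no step can be read from it to compound 4, which gives 33.7 nM in the same assay. No measured explanation bears on this result. The compounds shown leave open how large the effect of replacing 3-hydroxy-4-methoxyphenyl with 3-fluorophenyl is in numbers, as no two compounds with numbers differ in one place.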